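Ring carboxy group swapped for a hydroxymethyl-triazolylmethyl arm

The compounds below may be only part of what the source reports. "The series", "measured", "known", "first", "only" and "open" are said of these compounds alone.

Compound 1 `CC(C)=CCC[C@]1(C)/C=C/[C@@H](OC(=O)C=C(C)C)[C@](C)(O)/C=C/C(=O)/C(C(=O)O)=C\C1`: > 10000 nM
Compound 2 `CC(C)=CCC[C@]1(C)/C=C/[C@@H](OC(=O)C=C(C)C)[C@](C)(O)/C=C/C(=O)/C(C[Si](c2ccccc2)(c2ccccc2)C(C)(C)C)=C\C1`: 14400 nM

In a functional assay on HL-60 cells (Homo sapiens) for antiproliferative activity, read by MTT assay, with a stated time of 48 h (a lower number here means a stronger inhibitor, a higher number a weaker inhibitor), compound 1 sits at a limit of the assay, (the limit of > 10000 nM in this assay, at which 1 of the 2 values shown sits), so no number is known for it. Compound 2 gives a measured value, 14400 nM, and both compounds fall in the weak region. Compound 3 `CC(C)=CCC[C@]1(C)/C=C/[C@@H](OC(=O)C=C(C)C)[C@](C)(O)/C=C/C(=O)/C(Cn2cc(CO)nn2)=C\C1` carries the change ((4-(hydroxymethyl)-1H-1,2,3-triazol-1-yl)methyl in place of carboxy on a double-bonded ring carbon). With compound 1 known only as a limit, the step from compound 1 to compound 3 is expected to be a step that the limit leaves unreadable from compound 1 to compound 3, meaning nothing clearly beyond the scatter. Compound 3 is therefore expected to come in around 12000 nM, estimated between 4000 nM and 40000 nM, with a fair chance that only a limit is reported.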

Compound 3, half-maximal inhibitory concentration: 3200 nM
For compound 3 the middle estimate is 3.8-fold (0.57 log units) above the measured one; measured number outside the range, below it.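

In this assay, (4-(hydroxymethyl)-1H-1,2,3-triazol-1-yl)methyl in place of carboxy on the double-bonded ring carbon gives an at least 3.1-fold lower number from compound 1 to compound 3 (0.49 log units; beyond the scatter). The value of compound 1 is a limit, not a number: the limit of > 10000 nM in this assay, at which 1 of the 3 values shown sits. This ring carbon therefore carries an arm with a five-membered aromatic ring and gives a measured value that is beyond the scatter of that limit, which the carboxy compound could not show.

As far as these compounds go, whether the step belongs to the triazole ring or to its hydroxymethyl stays open. An arm ending in an amine, or a longer chain on the same ring, would bear on this.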